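This account rests on a few compounds, and the source may have more. Where it says the series, first, only, none or still open, it means among the compounds named here.

Measured compounds:
- compound 1 `Cc1ccccc1-c1nn(-c2ccc(Cl)cc2)cc1CNCCN1CCN(C)CC1` — in an ADME assay on Huh-7 cells (Homo sapiens) for cytotoxicity (a higher number here means that more compound is tolerated, a lower number that less compound is tolerated), compound 1 gives 17000 nM
- compound 2 `CCOC(=O)Cn1cc(CNCCN2CCN(C)CC2)c(-c2ccccc2C)n1` — compound 2 gives only a limit, > 20000 nM
- compound 3 `Cc1ccccc1-c1nn(C(C)C)cc1CNCCN1CCN(C)CC1` — compound 3 likewise gives only a limit, > 20000 nM

Compound 3 therefore stands at the limit of this assay, not at a number, and the same holds for compound 2 (the limit of > 20000 nM in this assay, at which 2 of the 3 values shown sit). Among the measured compounds shown here, the one step that reaches compound 3 from a number is an at least 1.1-fold higher number from compound 1 to compound 3 (0.07 log units; that floor lies within the scatter), which rests on the limit and says no more than that compound 3 is at least as well tolerated as compound 1.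

Compound 4 `Cc1ccccc1-c1nn(-c2ccc(F)c(F)c2)cc1CNCCN1CCN(C)CC1` differs from compound 3 in this way: 3,4-difluorophenyl in place of isopropyl on an aromatic nitrogen. The closest measured comparison is the reverse of that step, since compound 1 carries 4-chlorophenyl at the same aromatic nitrogen and gives a number. Compound 2, with (ethoxycarbonyl)methyl there, adds nothing readable, as a step that the two limits leave unreadable from compound 2 to compound 3 shows. A return from isopropyl to an aryl group is thus expected to move compound 4 back toward compound 1, so the step of an at least 1.1-fold lower number from compound 3 to compound 4 (0.07 log units; that floor lies within the scatter) is expected to be small and downward or within the scatter. Compound 4 is estimated at 17000 nM, within 7000 nM to 40000 nM.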

Compound 4, half-maximal cytotoxic concentration: > 20000 nM
Compound 4: only a limit was reported (the forecaster's own chance of this, stated with the estimate: 35%); at least 1.1-fold (0.07 log units) between middle value and limit.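

In this assay compound 4 gives only a limit, > 20000 nM. An aryl group on this aromatic nitrogen therefore does not in itself bring the value down to a number, since 3,4-difluorophenyl ends at the same limit as isopropyl and (ethoxycarbonyl)methyl, while the steps between these limits cannot be read. The one readable step is an at least 1.1-fold higher number from compound 1 to compound 4 (0.07 log units; that floor lies within the scatter), so swapping 4-chlorophenyl for 3,4-difluorophenyl may change little or much, and the series now sits largely at one ceiling: the limit of > 20000 nM in this assay, at which 3 of the 4 values shown sit.

As far as these compounds go, how far compound 2, compound 3 and compound 4 lie past the limit remains open, so these groups cannot be ranked against one another. Also open, from the compounds shown here alone, is how this assay would respond to a carboxylic acid or a primary amine on a longer chain at this nitrogen.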